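The source may hold more compounds than are shown below. What is called first, only, known or untested is meant among the compounds shown, and "the series" means these compounds.

Measured so far in an assay on isolated protein for inhibition of kallikrein-7 (Mus musculus), read by fluorescence, with stated times of 10 min and 30 min; a lower number here means a stronger inhibitor, a higher number a weaker inhibitor:
compound 1 `CC1=NC(c2cn(S(=O)(=O)c3cccs3)c3ccc(C)cc23)CN1`, 22000 nM
compound 2 `CC1=NC(c2cn(S(=O)(=O)c3ccccc3Cl)c3ccc(C)cc23)CN1`, 1500 nM
compound 3 `CC1=NC(c2cn(S(=O)(=O)c3ccccc3F)c3ccc(C)cc23)CN1`, 6400 nM

Compound 1 stands at the highest number of the three; compound 3 lies nearest to it and compound 2 furthest away. Compound 4 `CC1=NC(c2cn(S(=O)(=O)c3ccccc3C#N)c3ccc(C)cc23)CN1` differs from compound 1 by 2-cyanophenyl in place of thiophen-2-yl on a sulfonyl sulfur. Within the data shown here, two measured steps bear on this exchange, both replacing the same thiophen-2-yl with a substituted phenyl on the sulfonyl sulfur: a 15-fold lower number from compound 1 to compound 2 (1.17 log units; beyond the scatter) and a 3.4-fold lower number from compound 1 to compound 3 (0.54 log units; beyond the scatter). Between the two phenyl cases the gap is a 4.3-fold higher number from compound 2 to compound 3 (0.63 log units; beyond the scatter), so the size of the gain depends on the substituent. For compound 4 a lower number is expected, by a step of roughly a 7.3-fold lower number from compound 1 to compound 4 (0.87 log units; beyond the scatter). The estimate for compound 4 in this assay is 3000 nM, with a range from 800 nM to 12000 nM.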

Compound 4, half-maximal inhibitory concentration: 11000 nM
Compound 4: the middle estimate sits 3.7-fold (0.56 log units) below what was measured; low and high end bracket the measured number.
By their numbers in this assay, from the lowest: compound 2; then compounds 3, 4 and 1 (each within the scatter of the next, the first and the last beyond it).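

Replacing thiophen-2-yl with a substituted phenyl on the sulfonyl sulfur does not in itself secure a gain: 2-cyanophenyl gives a 2.0-fold lower number from compound 1 to compound 4 (0.30 log units; within the scatter) and stays level with the fluoro compound, with a 1.7-fold higher number from compound 3 to compound 4 (0.24 log units; within the scatter) for that exchange. Chloro stands apart from cyano, with a 7.3-fold higher number from compound 2 to compound 4 (0.87 log units; beyond the scatter) on this exchange, so the clear gain so far rests on compound 2 alone. No evidence on the cause of these differences is available here.

Open, from the compounds shown here alone, is whether 2-bromophenyl or 2-methylphenyl would match the 2-chlorophenyl of compound 2. Unsubstituted phenyl would show what the substituent itself contributes.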